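Compound 4: a new aryl group on the amine nitrogen

The source may report more compounds than this note shows. Statements on the series, on what has been measured and on what is new or still open speak of the compounds shown alone.

Measured in a functional assay on MCF7 cells (Homo sapiens) for inhibition, read by sulforhodamine B assay; on this read-out lower numbers stand for stronger inhibition and higher numbers for weaker inhibition:
- Compound 1 `O=C1C(Nc2ccc(I)cc2)=CC(=O)c2c1nc1n2[C@H]2OC[C@@H](O)[C@H]2OC1`: 3890 nM
- Compound 2 `O=C1C=C(N2CCC2)C(=O)c2c1nc1n2[C@H]2OC[C@@H](O)[C@H]2OC1`: > 16000 nM (a limit)
- Compound 3 `O=C1C=C(NC2CCCC2)C(=O)c2c1nc1n2[C@H]2OC[C@@H](O)[C@H]2OC1`: > 16000 nM (a limit)

Compound 3 has no numerical value, only a limit of > 16000 nM. Compound 2 shares that position, which is the limit of > 16000 nM in this assay, at which 2 of the 3 values shown sit. Compound 1 is the only one of the three with a numerical value in this assay.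

The next compound, compound 4 `CCOc1ccccc1NC1=CC(=O)c2nc3n(c2C1=O)[C@H]1OC[C@@H](O)[C@H]1OC3`, departs from compound 3 by one change: 2-ethoxyphenyl in place of cyclopentyl on an amine nitrogen. The only measured step among these compounds is a step that the two limits leave unreadable from compound 2 to compound 3. It offers no size to carry over to the new change. The closest guide is compound 1, which also has a six-membered aromatic ring of carbon only on an amine nitrogen and gives 3890 nM in this assay. This is a single compound with a different group, so it supports only a tentative expectation of stronger inhibition than compound 3 shows, and compound 4 may still stay at the limit. The expected change is an at least 2.2-fold lower number from compound 3 to compound 4 (0.35 log units; beyond the scatter). For compound 4 the estimate is 7000 nM, with an expected range from 2500 nM to 20000 nM.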

Compound 4, half-maximal inhibitory concentration: > 4000 nM
Compound 4 was reported as a limit; the forecaster's own chance of this, stated with the estimate: 30%; the middle value is on the limit's open side.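

In this assay compound 4 gives > 4000 nM as a limit and not a number. Compound 3 is likewise reported only as a limit, so the step from compound 3 to compound 4 cannot be read. The compounds shown leave open whether 2-ethoxyphenyl in place of cyclopentyl on the amine nitrogen changes inhibition at all.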